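This account rests on a few compounds, and the source may have more. Where it says the series, first, only, none or still open, it means among the compounds named here.

Measured in a functional assay on SJSA-1 cells (Homo sapiens) for cytotoxicity, read by MTT assay, with a stated time of 5 days; a lower number here means a stronger inhibitor, a higher number a weaker inhibitor:
- compound 1 `CCOc1cc(C(C)(C)C)ccc1C1=N[C@@](C)(c2ccc(Cl)cc2)[C@@](C)(c2ccc(Cl)cc2)N1C(=O)N1CCN(CCNS(C)(=O)=O)CC1`: 200 nM
- compound 2 `CCOc1cc(C(C)(C)C)ccc1C1=N[C@@](C)(c2ccc(Cl)cc2)[C@@](C)(c2ccc(Cl)cc2)N1C(=O)N1CCN(CCNC(C)=O)CC1`: 100 nM

Compound 2, at 100 nM, stands within the scatter of compound 1, at 200 nM, so neither can be ranked above the other. The next compound to be considered is compound 3 `CCOc1cc(C(C)(C)C)ccc1C1=N[C@@](C)(c2ccc(Cl)cc2)[C@@](C)(c2ccc(Cl)cc2)N1C(=O)N1CCN(CC(=O)N2CCCC2)CC1`, which differs from compound 2 as follows: (pyrrolidin-1-yl)carbonyl in place of acetamidomethyl on a saturated chain carbon bound to an amine nitrogen in a ring. Put another way, 2-acetamidoethyl gives way to ((pyrrolidin-1-yl)carbonyl)methyl. Among the compounds with values here, only one measured step bears on this, and only indirectly: a 2.0-fold lower number from compound 1 to compound 2 (0.30 log units; within the scatter), with acetyl in place of methylsulfonyl on an amine nitrogen. Within the data shown here, no measured compound tests the new group itself, so the data give no direction for the change, and no shift beyond the scatter is expected in this assay. The expected step is a 1.2-fold higher number from compound 2 to compound 3 (0.08 log units; within the scatter). For compound 3 the estimated value is 120 nM, with an expected range from 40 nM to 350 nM.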

Compound 3, half-maximal inhibitory concentration: 300 nM
Estimate against measurement, compound 3: 2.5-fold (0.40 log units) below, within the range that was stated.
By their numbers in this assay, from the lowest: compounds 2, 1 and 3 (each within the scatter of the next, the first and the last beyond it).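

In this assay, within the data shown here, this is the first change made on the saturated chain carbon bound to an amine nitrogen in a ring, and it gives the first step beyond the scatter: a 3.0-fold higher number from compound 2 to compound 3 (0.48 log units; beyond the scatter), with (pyrrolidin-1-yl)carbonyl in place of acetamidomethyl. Against the (methanesulfonamido)methyl group the same entering group gives a 1.5-fold higher number from compound 1 to compound 3 (0.18 log units; within the scatter), so the modest step appears against only one of the two earlier side chains. No measurement of any other kind is available to account for the step.

The compounds shown leave open whether the pyrrolidine ring or the loss of the amide hydrogen carries the step. A dimethylamide or a piperidine amide in the same place would test the ring, and a longer chain would test the distance from the ring amine nitrogen.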